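The source may hold more compounds than are shown below. What is called first, only, known or untested is meant among the compounds shown, and "the series" means these compounds.

Series notes. Compound 1 `CC(/C=C/CC(C)CCCC(C)C)=C\C(=O)OC(C)C` is the more lipophilic of the two measured compounds in a physicochemical assay for lipophilicity; on this read-out higher numbers stand for higher lipophilicity and lower numbers for lower lipophilicity: compound 1 gives 7.15, and compound 2 `COC(C)(C)C(O)CCC(C)C/C=C/C(C)=C/C(=O)OC(C)C` gives 3.86. Within the data shown here, the single measured step, a number 3.29 log units lower from compound 1 to compound 2 (beyond the scatter), concerns a different site and offers no direct guide here. Compound 3 `CC(/C=C/CC(C)CCCC(C)C)=C\C(=O)NCC(C)C` differs from compound 1 by isobutylamino in place of isopropoxy on a carbonyl carbon. Among the measured compounds shown here, no measured step covers this change, so the expectation rests on general experience with such exchanges: a moderate decrease is expected, a number 0.95 log units lower from compound 1 to compound 3 (beyond the scatter). Compound 3 is therefore estimated at 6.2, with a range from 5.4 to 7.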

Compound 3, partition coefficient: 6.19
Beside the measured number, compound 3's estimate is 0.01 log units above it, within the range that was stated.
By their numbers in this assay, from the lowest: compound 2; then compound 3; then compound 1.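

At the carbonyl carbon, the core of compound 1 gets its first measured step in this assay: isobutylamino in place of isopropoxy gives a number 0.96 log units lower from compound 1 to compound 3 (beyond the scatter) and stays modest in size. Among these compounds, the exchange replaces a group with 0 hydrogen-bond donors by one with 1 hydrogen-bond donor, and it also changes the chain from isopropyl to isobutyl, so the single step cannot separate these two differences. Nothing measured here bears on what lies behind this step. Open, from the compounds shown here alone, is how a dimethylamino group at the same carbonyl carbon, which lacks the amide hydrogen, would compare with isobutylamino. Also open, going by these compounds, is how an isopropylamino group, which keeps the chain of the ester, would compare.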